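Methyl to nitro on the phenoxy ring of the series

The compounds below may be only part of what the source reports. "The series", "measured", "known", "first", "only" and "open" are said of these compounds alone.

Two compounds of the series have numbers in a physicochemical assay for lipophilicity, in phosphate buffer, measured as octanol-water partition, with a stated time of 24 h; a lower number here means a more polar compound, a higher number a more lipophilic compound. Compound 1 `Cc1ccc(Oc2ccc(/C=N/NC(=O)CSc3nc4ccccc4s3)cc2)cc1` gives 5.7 in this assay. Compound 2 `Cc1ccc(Oc2ccc(/C=N/Nc3nc4ccccc4s3)cc2)cc1` gives 5.4 in this assay, a value within the scatter of that of compound 1. Compound 3 `O=C(CSc1nc2ccccc2s1)N/N=C/c1ccc(Oc2ccc([N+](=O)[O-])cc2)cc1` has not been measured in this assay. It differs from compound 1 by nitro in place of methyl on an aromatic carbon. Going by the values given here, no measured pair of the series shows this change, so its size is unknown here. The step from compound 1 to compound 3 is expected to be downward and beyond the scatter, at a number 0.80 log units lower from compound 1 to compound 3 (beyond the scatter). Compound 3 is therefore estimated at 4.9 in this assay, within 4.4 to 5.5.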

Compound 3, partition coefficient: 5.3
Estimate against measurement, compound 3: 0.40 log units below; low and high end bracket the measured number.
By their numbers in this assay, from the lowest: compounds 3, 2 and 1 (each within the scatter of the next, the first and the last beyond it).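

In this assay, going by these compounds alone, the change from 4-methylphenoxy to 4-nitrophenoxy gives the first readable step at this position, a number 0.40 log units lower from compound 1 to compound 3 (beyond the scatter) and modest in size. The substituent on this aromatic carbon therefore registers in this read-out with the rest of compound 1 held fixed. Nothing on hand bears on the origin of this step.

Going by these compounds, whether the same change gives a step of similar size on the core of compound 2 remains open. Also open, on these data alone, is where an amine or a carboxylic acid at this place would fall relative to methyl and nitro.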